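Imidazole Amide to Urea on a Sulfonyl Tetrahydronaphthalene Core

A few compounds are considered here, and "the series" means these few. Any claim that something is new, unique, unknown or untested is made for them only; others in the source may bear on it.

Compound 1, `COc1cccc(S(=O)(=O)c2ccc3c(c2)CCC[C@H]3CN)c1`, gives 0.398 nM in an assay on isolated protein for displacement of a labelled ligand from 5-hydroxytryptamine receptor 6 (Homo sapiens); on this read-out higher numbers stand for weaker inhibition and lower numbers for stronger inhibition.
Compound 2, `NC[C@@H]1CCCc2cc(S(=O)(=O)c3cc[nH]c3)ccc21`, gives 0.316 nM.
Compound 3, `O=C(NC[C@@H]1CCCc2cc(S(=O)(=O)c3cccc(F)c3)ccc21)c1ncc[nH]1`, gives 15.9 nM.

Three compounds share a core and differ in the group attached to the sulfone and in what sits on the aminomethyl arm. Compound 1 and compound 2 carry a free amine on that arm, and their numbers in this assay are the lowest of the set. Compound 3 carries an amide built from an imidazole and stands highest of the three numbers; its nearest neighbour is compound 1 with a far lower number, and compound 2 lies further still, both gaps beyond the scatter.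

The next compound, compound 4, `NC(=O)NC[C@@H]1CCCc2cc(S(=O)(=O)c3cccc(F)c3)ccc21`, keeps the fluorophenyl sulfone of compound 3 but changes the arm: amino in place of 1H-imidazol-2-yl on a carbonyl carbon. The ((1H-imidazol-2-yl)carbonyl)amino group becomes a ureido group, a much smaller attachment that still carries a carbonyl on the nitrogen of the arm. Because compound 3 gives 15.9 nM while the free-amine compound 1 gives 0.398 nM, shrinking the acyl group is expected to move the number down somewhat, but not all the way back, since a carbonyl remains. The expected step is a 2.0-fold lower number from compound 3 to compound 4 (0.30 log units; within the scatter), modest and possibly within the scatter. For compound 4 the estimate is 8 nM, with a range from 2.5 nM to 30 nM.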

Compound 4, inhibition constant: 0.2 nM
Estimate against measurement, compound 4: 40-fold (1.60 log units) above, outside the stated range (below it).
By their numbers in this assay, from the lowest: compounds 4, 2 and 1 (each within the scatter of the next); then compound 3.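

In this assay, for the compounds shown here, placing amino instead of 1H-imidazol-2-yl on the carbonyl carbon gives an 80-fold lower number from compound 3 to compound 4 (1.90 log units; beyond the scatter), the first step in this set that isolates a single change, and it shows that this position responds strongly to the group on that carbon. The carbonyl on the nitrogen of the arm and the sulfone side are the same in both compounds, so a carbonyl on the arm does not by itself bring a high number, as compound 4 at 0.2 nM shows. Nothing shown here explains why the swap has so large an effect, and the single step cannot say whether it is the loss of the ring or of the extra heavy atoms that counts.

Going by these compounds alone, with only two groups on this carbonyl carbon, it stays open where the number would fall for a methyl group, a dimethylamino group or a phenyl ring, which would help separate ring from size. From the compounds shown here alone, it also stays open whether the same swap gives a step of similar size when the sulfone carries the 3-methoxyphenyl group of compound 1 rather than the fluorophenyl group.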